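Swapping a pyridine ring for a plain chain

The source may hold more compounds than are shown below. What is called first, only, known or untested is meant among the compounds shown, and "the series" means these compounds.

In a functional assay on a cell-free system (plasma, Homo sapiens) for inhibition, with Plasma (Rattus norvegicus) as the target (on this read-out lower numbers stand for stronger inhibition and higher numbers for weaker inhibition), the measured values are these
- compound 1 `O=c1cc(N2CCNCC2)c2c(OCc3ccccc3)cccc2o1` gives 187000 nM
- compound 2 `O=c1cc(N2CCNCC2)c2ccc(OCc3ccccc3)cc2o1` gives 16300 nM
- compound 3 `Cc1c(OCc2cccnc2)ccc2c(N3CCNCC3)cc(=O)oc12` gives 980 nM

Lower numbers mean stronger inhibition here, so compound 3 stands best of the three. Its value lies well beyond the usual scatter from both others, with compound 2 the nearer at 16300 nM and compound 1 the further at 187000 nM.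

The next compound to be tested is compound 4 `CCCCOc1ccc2c(N3CCNCC3)cc(=O)oc2c1C`. It keeps the shared core of compound 3 and changes one place, with propyl in place of pyridin-3-yl on a saturated chain carbon bound to an oxygen on an aromatic ring. Cut one bond further out, this reads as (pyridin-3-yl)methoxy to butoxy.

Among the measured compounds shown here, no measured pair of compounds shows this kind of change, so the expectation rests on little. For the measured compounds named here, with compound 3 at 980 nM as the lowest number so far, a higher value seems more likely than a lower one. The expected change is a moderate weakening, an estimated 2.6-fold higher number from compound 3 to compound 4 (0.41 log units; beyond the scatter) in this assay and one that may not clear the scatter by much. Compound 4 is estimated at 2500 nM with an expected range from 500 nM to 12000 nM in all.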

Compound 4, half-maximal inhibitory concentration: 2790 nM
Estimate against measurement, compound 4: 1.1-fold (0.05 log units) below; the range from low to high includes it.
By their numbers in this assay, from the lowest: compound 3; then compound 4; then compound 2; then compound 1.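

Going from (pyridin-3-yl)methoxy to butoxy in this assay weakens inhibition, with a 2.8-fold higher number from compound 3 to compound 4 (0.45 log units; beyond the scatter) as the step, which is modest in size though beyond the usual scatter. This is the first single change shown at this place on the shared core, and it tells that the six-membered aromatic ring with its nitrogen is not needed for inhibition to stay in the same general range, since a propyl with no ring and no hydrogen-bond acceptor can take its place at a modest cost. Nothing measured here says why the pyridine compound holds the lower number, whether the ring, its nitrogen or simply the larger group matters.

Among the compounds shown here, only one chain length appears at this place, so it remains open whether a shorter ethoxy chain, a longer hexyloxy chain or a chain ending in an amine would land closer to compound 3 or further from it. It is equally open how much the position of the ring nitrogen counts, as (pyridin-2-yl)methoxy and (pyridin-4-yl)methoxy do not appear among these compounds.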